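The source may hold more compounds than are shown below. What is called first, only, known or untested is meant among the compounds shown, and "the series" means these compounds.

Measured compounds in an ADME assay on CCRF-CEM cells (Homo sapiens) for inhibition, read by cell counting; a lower number here means a stronger inhibitor, a higher number a weaker inhibitor:

compound 1 `CSc1nc(NCCCCNc2ccnc3cc(Cl)ccc23)c(C#N)c(-c2ccccc2)n1` gives 5200 nM
compound 2 `CSc1nc(NCCCCNc2ccnc3cc(Cl)ccc23)c(C#N)c(-c2cccc([N+](=O)[O-])c2)n1` gives 2100 nM
compound 3 `CSc1nc(-c2ccc([N+](=O)[O-])cc2)c(C#N)c(N2CCN(c3ccnc4cc(Cl)ccc34)CC2)n1` gives 156000 nM

Compound 2 has the lowest number of the three in this assay; compound 1 is its nearest neighbour and compound 3 lies furthest from it. Compound 3 differs from compound 2 in more than one place, so its value is noted only as a number and not as a step.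

Compound 4 `CSc1nc(NCCCCNc2ccnc3cc(Cl)ccc23)c(C#N)c(-c2ccc(C)cc2)n1` is not yet measured. Its change from compound 2 is 4-methylphenyl in place of 3-nitrophenyl on an aromatic carbon. Within the data shown here, the one measured step that bears on this position is a 2.5-fold lower number from compound 1 to compound 2 (0.39 log units; beyond the scatter), which shows that removing the nitro group from that ring raises the number by a modest but real margin. Among the measured compounds shown here, compound 4 neither keeps the nitro group nor returns to hydrogen, and no measured compound carries a methyl at this ring; the expectation is therefore anchored between compound 2 and compound 1, closer to compound 1. Compound 4 is expected to give 4500 nM, within 1500 nM to 14000 nM, an estimated step of a 2.1-fold higher number from compound 2 to compound 4 (0.33 log units; beyond the scatter).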

Compound 4, half-maximal inhibitory concentration: 4900 nM
Compound 4: middle estimate off by 1.1-fold (0.04 log units), on the low side, and the stated range covers the measured number.
By their numbers in this assay, from the lowest: compound 2; then compounds 4 and 1 (each within the scatter of the next); then compound 3.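

In this assay, 4-methylphenyl in place of 3-nitrophenyl on this aromatic carbon gives a 2.3-fold higher number from compound 2 to compound 4 (0.37 log units; beyond the scatter), so compound 2 now stands apart from a substituted phenyl as well as from the plain phenyl of compound 1. Methyl in place of hydrogen on that ring gives a 1.1-fold lower number from compound 1 to compound 4 (0.03 log units; within the scatter), so at this ring position a 4-methyl group does not separate from hydrogen, and among these three compounds only the 3-nitrophenyl compound stands apart. Nothing at hand accounts for this difference.

From the compounds shown here alone, the step from compound 2 to compound 4 changes both the group and its place on the ring, so the share of each stays open. Also open, going by these compounds, is how a 3-methylphenyl ring, or a phenyl ring bearing an amine or a carboxylic acid, would compare at this carbon.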